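A few compounds are considered here, and "the series" means these few. Any claim that something is new, unique, unknown or untested is made for them only; others in the source may bear on it.

Compound 1, `COc1ccccc1-c1cn(C[C@H](O)[C@H]2OC(=O)C(OCc3ccccc3)=C2OCc2ccccc2)nn1`, in a functional assay on SW-620 cells (Homo sapiens) for antiproliferative activity, read by MTT assay, with a stated time of 72 h (on this read-out higher numbers stand for weaker inhibition and lower numbers for stronger inhibition), gives > 100000 nM.
Compound 2, `COc1ccccc1-c1cn(C/C=C2\OC(=O)C(OCc3ccccc3)=C2OCc2ccccc2)nn1`, in this assay gives > 100000 nM.

Neither of these is a number: compound 1 sits at the limit of > 100000 nM in this assay, at which 2 of the 2 values shown sit, so where compound 1 stands among the values shown cannot be placed more closely. Compound 3, `C[Si](C)(C)c1cn(C[C@H](O)[C@H]2OC(=O)C(OCc3ccccc3)=C2OCc2ccccc2)nn1`, differs from compound 1 in a single spot: a group of 4 heavy atoms (3 carbon, 1 silicon; no ring) in place of a group of 8 heavy atoms (7 carbon, 1 oxygen; one six-membered aromatic ring of carbon only), on an aromatic carbon. Within the data shown here, no step between measured compounds is available to guide the change, and a value of this kind can only be confirmed or lifted. The step that the limit leaves unreadable from compound 1 to compound 3 is expected to be none beyond the scatter. Compound 3 is therefore estimated at 150000 nM, within a range from 50000 nM to 500000 nM, most likely again reported only as a limit.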

Compound 3, half-maximal inhibitory concentration: 56000 nM
Compound 3: the middle estimate sits 2.7-fold (0.43 log units) above what was measured, within the range that was stated.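

In this assay compound 3 gives 56000 nM as a true reading, so a group of carbon and silicon on this aromatic carbon, in place of 2-methoxyphenyl, yields a value that can be read. Compound 1 gives > 100000 nM as a limit, not a number. The change gives an at least 1.7-fold lower number from compound 1 to compound 3 (0.25 log units; that floor lies within the scatter) and its true size cannot be read: the limit of > 100000 nM in this assay, at which 2 of the 3 values shown sit.

From the compounds shown here alone, what an amine, a carboxylic acid or a longer chain on this aromatic carbon would give stays open. Compound 3 carries a silicon atom and lacks the ring of 2-methoxyphenyl. The data do not tell these two differences apart.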